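Chromene chalcones: aryl swap toward a bromo-hydroxyphenyl analogue

The compounds below may be only part of what the source reports. "The series", "measured", "known", "first", "only" and "open" are said of these compounds alone.

Compound 1 `COc1ccc(/C=C/C(=O)c2ccc(OC)c3c2OC(C)(C)C=C3)c(F)c1`: in a functional assay on SW-620 cells (Homo sapiens) for antiproliferative activity, read by MTT assay, with a stated time of 24 h (a lower number here means a stronger inhibitor, a higher number a weaker inhibitor), compound 1 gives 6570 nM.
Compound 2 `COc1ccc(C(=O)/C=C/c2cccc(Cl)c2)c2c1C=CC(C)(C)O2`: in this assay compound 2 gives only a limit, > 10000 nM.

Compound 2 thus stands at the limit of > 10000 nM in this assay, at which 1 of the 2 values shown sits, with no number beneath it. Compound 3 `COc1ccc(C(=O)/C=C/c2ccc(O)c(Br)c2)c2c1C=CC(C)(C)O2` carries 3-bromo-4-hydroxyphenyl in place of 3-chlorophenyl on a double-bonded chain carbon bound to a double-bonded chain carbon. Within the data shown here, the only measured step, an at least 1.5-fold higher number from compound 1 to compound 2 (0.18 log units; that floor lies within the scatter), concerns a different aryl swap and sits within the scatter, so it gives little guidance. No step beyond the scatter is therefore expected in this assay; the expected step is an at least 1.1-fold lower number from compound 2 to compound 3 (0.04 log units; that floor lies within the scatter). Compound 3 is estimated at 9000 nM, with a range from 3000 nM to 30000 nM.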

Compound 3, half-maximal inhibitory concentration: > 10000 nM
Compound 3 gave a limit, no number; the forecaster's own chance of this, stated with the estimate: 50%; middle value at least 1.1-fold (0.04 log units) from the limit.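

In this assay compound 3 gives > 10000 nM, a limit and not a number, so a hydrogen-bond donor on the aryl group at this place does not yield a readable value. The step between the two limits cannot be read, leaving 3-bromo-4-hydroxyphenyl and 3-chlorophenyl unranked: the limit of > 10000 nM in this assay, at which 2 of the 3 values shown sit. Replacing 2-fluoro-4-methoxyphenyl gives an at least 1.5-fold higher number from compound 1 to compound 3 (0.18 log units; that floor lies within the scatter). From the compounds shown here alone, whether an amine or a carboxylic acid on this aryl ring would give a value under the limit stays open. Going by these compounds, the actual values of compound 2 and compound 3 also stay open.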